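A few compounds are considered here, and "the series" means these few. Any claim that something is new, unique, unknown or untested is made for them only; others in the source may bear on it.

Working notes on the series. Of the compounds shown here, three share the same side chain and have been measured in a physicochemical assay for lipophilicity, using the shake flask method, in phosphate buffer, measured as octanol-water partition, with a stated time of 30 min, at pH 7.4; on this read-out higher numbers stand for higher lipophilicity and lower numbers for lower lipophilicity. Compound 1 `Cc1nccn1-c1cnc(NCc2c(F)ccc3c2CCO3)c2cn[nH]c(=O)c12` gives 2.1. Compound 2 `O=C(Nc1cnc(NCc2c(F)ccc3c2CCO3)n2cnnc12)c1cccnc1` gives 2, and compound 3 `CN(c1cccnc1)c1cnc(NCc2c(F)ccc3c2CCO3)n2cnnc12` gives 2.6. Compound 1 thus stands second highest of the three: its gap to compound 2 is within the scatter, while compound 3 sits beyond it. Among the measured compounds shown here, the one single-point step measured so far, a number 0.60 log units higher from compound 2 to compound 3 (beyond the scatter), is a modest rise, but it concerns a different exchange on the other core and does not touch the position changed here.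

Compound 4 `Cc1nn(C)cc1-c1cnc(NCc2c(F)ccc3c2CCO3)c2cn[nH]c(=O)c12` differs from compound 1 by 1,3-dimethyl-1H-pyrazol-4-yl in place of 2-methyl-1H-imidazol-1-yl on an aromatic carbon. For the measured compounds named here, no measured pair covers this exchange, so the measured step offers no direct guide. Given the similar size and make-up of the leaving and entering groups, only a small upward move, if any, is expected, likely near the edge of the scatter. Compound 4 is expected to give 2.4, with a range of 2 to 2.8, corresponding to an estimated step of a number 0.30 log units higher from compound 1 to compound 4 (within the scatter).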

Compound 4, distribution coefficient: 2.8
The estimate for compound 4 lay 0.40 log units below the measured number; the measured number falls inside the stated range.
By their numbers in this assay, from the lowest: compounds 2 and 1 (each within the scatter of the next); then compounds 3 and 4 (each within the scatter of the next).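

Among the compounds shown here, this is the first step read at this aromatic carbon of the shared core: in this assay, the exchange of 2-methyl-1H-imidazol-1-yl for 1,3-dimethyl-1H-pyrazol-4-yl gives a number 0.70 log units higher from compound 1 to compound 4 (beyond the scatter). The read-out therefore responds to this position even though both groups are five-membered aromatic rings with 2 hetero atoms, 0 hydrogen-bond donors, 2 hydrogen-bond acceptors and no net charge, so those counted features do not by themselves set the value here. No evidence is at hand on the origin of this step.

The compounds shown leave open whether the step follows the ring itself or its methyl groups, a question that an unsubstituted pyrazol-4-yl would address. They also leave open how far the read-out would move with a group of another kind here, such as an amine or a carboxylic acid.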